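Dropping the nitro group from compound 2: an expected step

A few compounds are considered here, and "the series" means these few. Any claim that something is new, unique, unknown or untested is made for them only; others in the source may bear on it.

Measured so far:
compound 1 `Cc1nc2c3ccccc3ccc2c2nc3c(ccc4ccccc43)c(-c3cc([N+](=O)[O-])ccc3N)c12` — 5770 nM
compound 2 `Cc1nc2c3ccccc3ccc2c2nc3c(ccc4ccccc43)c(-c3cccc([N+](=O)[O-])c3)c12` — 50700 nM

Compound 2 stands at the highest of the two numbers in a functional assay on HeLa cells (Homo sapiens) for cytotoxicity, read by MTT assay, with a stated time of 48 h; on this read-out lower numbers stand for stronger inhibition and higher numbers for weaker inhibition; its nearest neighbour is compound 1, whose value in this assay is lower by an 8.8-fold higher number from compound 1 to compound 2 (0.94 log units; beyond the scatter). That step is the only one measured, and it concerns an amino group, not the nitro group: hydrogen in place of amino on an aromatic carbon gave a higher number, beyond the scatter, in compound 2.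

Compound 3 `Cc1nc2c3ccccc3ccc2c2nc3c(ccc4ccccc43)c(-c3ccccc3)c12` has not been measured. It differs from compound 2 by hydrogen in place of nitro on an aromatic carbon. Going by the values given here, no measured pair shows what removing the nitro group does on this scaffold; the step from compound 1 to compound 2 bears on it only in that it shows the substituted phenyl ring is sensitive to change. Without a matching precedent, compound 3 is expected to sit close to compound 2 in this assay, with a step of a 1.1-fold higher number from compound 2 to compound 3 (0.04 log units; within the scatter) that stays within the scatter. The estimate for compound 3 is therefore 55000 nM, with a range from 18000 nM to 160000 nM.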

Compound 3, half-maximal inhibitory concentration: > 80000 nM
Compound 3 was reported as a limit; the forecaster's own chance of this, stated with the estimate: 20%; middle value at least 1.4-fold (0.16 log units) from the limit.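

In this assay compound 3 gives > 80000 nM and this value is a limit of the assay, not a number. The change from 3-nitrophenyl to phenyl gives an at least 1.5-fold higher number from compound 2 to compound 3 (0.19 log units; that floor lies within the scatter) so the pair shows no separation that can be told from the scatter, though it also shows that taking away the nitro group did not bring the number down in this series. With the step of an at least 13-fold higher number from compound 1 to compound 3 (1.14 log units; beyond the scatter) the result adds something the first two compounds could not show: the unsubstituted phenyl ring stands clearly apart from the 2-amino-5-nitrophenyl ring, and the size of that gap is a floor, not a measured distance.

How far compound 3 truly lies from compound 2 stays open, and the nitro group's share in the activity with it, since the reading ends at this point: the limit of > 80000 nM in this assay, at which 1 of the 3 values shown sits.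

Also open, as far as these compounds go, is whether an amine on the phenyl ring would hold its effect with no nitro group present, and whether a carboxylic acid or a nitrile in place of nitro would behave any differently on this core.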